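This account rests on a few compounds, and the source may have more. Where it says the series, first, only, none or still open, it means among the compounds named here.

The study concerns inhibitors of acid ceramidase, assessed in an assay on HEK293 cells for inhibition of acid ceramidase (Homo sapiens), read by fluorescence, with stated times of 10 min and 3 h; a higher number here means a weaker inhibitor, a lower number a stronger inhibitor. Of the compounds shown here, two have been measured so far. Compound 1, `O=C(NCCCCc1ccccc1)n1c2c(oc1=O)CCN(Cc1ccccc1)C2`, gives 436 nM in this assay. Compound 2, `CN1CCN(c2ccc3c(c2)oc(=O)n3C(=O)NCCCCc2ccccc2)C(=O)C1`, gives 52 nM in this assay, which is the lowest of the two numbers; its gap to compound 1 lies beyond the usual scatter, so compound 2 is the stronger inhibitor of the pair.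

The next compound, compound 3, `CN1CCC(c2ccc3c(c2)oc(=O)n3C(=O)NCCCCc2ccccc2)CC1`, differs from compound 2 in a single place: 1-methylpiperidin-4-yl in place of 4-methyl-2-oxopiperazin-1-yl on an aromatic carbon. Among the measured compounds shown here, no pair of measured compounds differs at that place, so nothing measured shows how this assay responds to such an exchange; compound 1 and compound 2 differ from each other in several places at once and offer no guide to this one change. In the absence of any measured step of this kind, the step of a 1.3-fold higher number from compound 2 to compound 3 (0.13 log units; within the scatter) is expected to stay within the scatter or reach only a little beyond it. Compound 3 is accordingly estimated at 70 nM in this assay, within a range from 25 nM to 200 nM.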

Compound 3, half-maximal inhibitory concentration: 129 nM
Estimate against measurement, compound 3: 1.8-fold (0.27 log units) below; measured number inside the range.
By their numbers in this assay, from the lowest: compound 2; then compound 3; then compound 1.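

In this assay the exchange of 4-methyl-2-oxopiperazin-1-yl for 1-methylpiperidin-4-yl on an aromatic carbon is a modest step, a 2.5-fold higher number from compound 2 to compound 3 (0.39 log units; beyond the scatter), and it gives the only measured sign that the assay responds to what stands at this place on the shared core. The group that enters differs from the group that leaves in several counted features at once: it has one hetero atom in its ring rather than two, no double bond outside aromatic rings, and one hydrogen-bond acceptor rather than two, so the step cannot be assigned to any one of these. Nothing measured here gives a reason for the size of this step.

The compounds shown leave open how morpholin-4-yl, or a piperidin-4-yl group without the methyl, would read at this aromatic carbon, and therefore which part of the exchange carries the step. They also leave open whether the step would keep its size if a shorter chain replaced the 4-phenylbutyl group on the shared core.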